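Swapping a hydroxy for a chloro on a cytotoxicity series

The compounds below may be only part of what the source reports. "The series", "measured", "known", "first", "only" and "open" are said of these compounds alone.

Measured so far:
- compound 1, `COc1ccc(C(=O)/C=C/c2cc3ccccc3[nH]c2=O)cc1`, 57000 nM
- compound 2, `O=C(/C=C/c1cc2ccccc2[nH]c1=O)c1ccc(O)cc1`, 34000 nM

These two compounds share a core and differ only at one group on the outer ring. In an ADME assay on ACHN cells (Homo sapiens) for cytotoxicity, read by sulforhodamine B assay, with a stated time of 24 h (a higher number here means that more compound is tolerated, a lower number that less compound is tolerated), compound 1 gives 57000 nM and compound 2 gives 34000 nM. The step of a 1.7-fold lower number from compound 1 to compound 2 (0.22 log units; within the scatter) is the only one measured, and it lies within the scatter. On the two numbers shown, compound 2 has the lower one, but the gap to compound 1 is too small to call a difference.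

Compound 3 is `O=C(/C=C/c1cc2ccccc2[nH]c1=O)c1ccc(Cl)cc1`, not yet measured. It differs from compound 2 by chloro in place of hydroxy on an aromatic carbon. Going by the values given here, no measured step involves a chloro, so the one known step, a 1.7-fold lower number from compound 1 to compound 2 (0.22 log units; within the scatter), bears on it only loosely: a change at this same position of the outer ring left this assay essentially unchanged. With nothing pointing in either direction, the expected step of a 1.2-fold higher number from compound 2 to compound 3 (0.07 log units; within the scatter) is none beyond the scatter. Compound 3 is therefore estimated at 40000 nM, with a range from 15000 nM to 110000 nM.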

Compound 3, concentration lethal to 50% of the cells: 90600 nM
Compound 3: middle estimate off by 2.3-fold (0.36 log units), on the low side; the range from low to high includes it.
By their numbers in this assay, from the lowest: compounds 2, 1 and 3 (each within the scatter of the next, the first and the last beyond it).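

In this assay, going from 4-hydroxyphenyl to 4-chlorophenyl gives a 2.7-fold higher number from compound 2 to compound 3 (0.43 log units; beyond the scatter), so a change at this position of the outer ring can shift the number beyond the scatter, though only modestly, with more of the chloro compound tolerated. Going by these compounds alone, the chloro and methoxy compounds cannot be told apart, since the step between them is a 1.6-fold higher number from compound 1 to compound 3 (0.20 log units; within the scatter); the only pair that separates is hydroxy and chloro, and the hydroxy and methoxy compounds stay within the scatter of each other, so these three compounds do not form a clean ranking of groups. The hydroxy brings 1 hydrogen-bond donor and the chloro brings 0, but this is only a count, and no measurement at hand accounts for the step.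

On these data alone, three groups on one position cannot show whether the effect is specific to hydroxy, so it remains open how an amine, a carboxylic acid or a longer chain on the oxygen would behave there. As far as these compounds go, it is also open whether the swap of hydroxy for chloro would give a step of similar size on a different core or at another place on this ring.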